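A few compounds are considered here, and "the series" means these few. Any claim that something is new, unique, unknown or untested is made for them only; others in the source may bear on it.

Measured compounds:
compound 1 `CC[C@H](C)[C@H](NC(=O)CN(c1nc(Cl)nc2[nH]cnc12)C1CC1)C(=O)O` – 30.3% in a functional assay on the whole organism (Tail, strain ICR) with Mus musculus as the target, in the tail flick test, with a stated time of 30 min, at a dose of 25 umol/kg by the oral route; a lower number here means a weaker effect, a higher number a stronger effect of the compound at the dose given
compound 2 `C[C@@H](O)[C@H](NC(=O)CN(c1nc(Cl)nc2[nH]cnc12)C1CC1)C(=O)OCc1ccccc1` – 21.9% in this assay
compound 3 `O=C(CN(c1nc(Cl)nc2[nH]cnc12)C1CC1)N[C@@H](CC(=O)OCc1ccccc1)C(=O)OCc1ccccc1` – 34.7% in this assay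

Compound 3 stands highest of the three numbers in this assay, though compound 1 lies within the scatter of it, and only compound 2 sits beyond the scatter below it, the step of a number 12.8 percentage points higher from compound 2 to compound 3 (beyond the scatter) being a modest one. Compound 4 `CC[C@H](C)[C@H](NC(=O)CN(c1nc(Cl)nc2[nH]cnc12)C1CC1)C(=O)OCc1ccccc1` has not yet been measured in this assay. It differs from compound 3 by sec-butyl in place of (benzyloxycarbonyl)methyl on a saturated chain carbon bound to an amide-type nitrogen and a carbonyl carbon. Within the data shown here, no measured step covers this exchange directly. Among the measured compounds shown here, the only step that touches the same place, a number 12.8 percentage points higher from compound 2 to compound 3 (beyond the scatter), is of modest size, and compound 1, which carries the same sec-butyl group as compound 4 with an acid in place of the ester, shows a value within the scatter of compound 3. Compound 4 is therefore expected to change little, with the step of a number 5.7 percentage points lower from compound 3 to compound 4 (within the scatter) not beyond the scatter. The estimate for compound 4 in this assay is 29%, between 16% and 43%.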

Compound 4, a percentage reported as activity, at one dose (the size of the read-out at that dose, not a potency): 41.4%
The estimate for compound 4 lay 12.4 percentage points below the measured number, within the range that was stated.
By their numbers in this assay, from the lowest: compounds 2, 1, 3 and 4 (each within the scatter of the next, the first and the last beyond it).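

In this assay, sec-butyl in place of (benzyloxycarbonyl)methyl gives a number 6.7 percentage points higher from compound 3 to compound 4 (within the scatter) and so, on this saturated chain carbon bound to an amide-type nitrogen and a carbonyl carbon, a ringless group of 4 heavy atoms and a group of 11 heavy atoms with an aromatic ring cannot be told apart. With sec-butyl held in place, benzyl in place of hydrogen on the oxygen can now be read alone, as a number 11.1 percentage points higher from compound 1 to compound 4 (beyond the scatter), while ethyl in place of hydroxy gives a number 19.5 percentage points higher from compound 2 to compound 4 (beyond the scatter), and both steps lie beyond the scatter. Nothing at hand explains these steps.

Going by these compounds, it remains open how an amine or a longer chain on this carbon would read. On these data alone, it is equally open whether benzyl on the oxygen would give a similar step with other groups at this carbon.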